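Swapping the benzyl substituent on a triazole thioether series

A few compounds are considered here, and "the series" means these few. Any claim that something is new, unique, unknown or untested is made for them only; others in the source may bear on it.

Compounds measured in a functional assay on HeLa cells (Homo sapiens) for antiproliferative activity, read by MTT assay, with a stated time of 24 h; on this read-out lower numbers stand for stronger inhibition and higher numbers for weaker inhibition:
compound 1 `Clc1ccccc1CSc1nnc(-c2ccc3c(c2)OCCO3)n1-c1ccccc1`: 29000 nM
compound 2 `COc1cccc(CSc2nnc(-c3ccc4c(c3)OCCO4)n2-c2ccccc2)c1`: > 100000 nM
compound 3 `Cc1ccccc1CSc1nnc(-c2ccc3c(c2)OCCO3)n1-c1ccccc1`: 36000 nM

Compound 2 reaches only the limit of this assay. Among the two true numbers, compound 3 has the higher one, though a 1.2-fold higher number from compound 1 to compound 3 (0.09 log units; within the scatter) lies within the scatter. Compound 4 `Fc1ccc(CSc2nnc(-c3ccc4c(c3)OCCO4)n2-c2ccccc2)cc1` is not yet measured; it differs from compound 3 by 4-fluorophenyl in place of 2-methylphenyl on a saturated chain carbon bound to a sulfur. For the measured compounds named here, two steps bear on this: an at least 3.4-fold higher number from compound 1 to compound 2 (0.53 log units; beyond the scatter) and an at least 2.7-fold lower number from compound 2 to compound 3 (0.44 log units; beyond the scatter), both showing that a 3-methoxyphenyl weakens the series, while 2-chlorophenyl and 2-methylphenyl sit close together. Going by the values given here, no measured compound carries a 4-fluorophenyl, so the direction is uncertain; a modest weakening is expected, a 1.5-fold higher number from compound 3 to compound 4 (0.18 log units; within the scatter). Compound 4 is therefore estimated at 55000 nM, within 20000 nM to 150000 nM.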

Compound 4, half-maximal inhibitory concentration: 46900 nM
For compound 4 the middle estimate is 1.2-fold (0.07 log units) above the measured one; low and high end bracket the measured number.
By their numbers in this assay, from the lowest: compounds 1, 3 and 4 (each within the scatter of the next). At a limit, above all of these: compound 2.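

In this assay, the 4-fluorophenyl group behaves like the two ortho-free... 

Correction, final text:

In this assay, the 4-fluorophenyl group cannot be told apart from the 2-methylphenyl group, a 1.3-fold higher number from compound 3 to compound 4 (0.11 log units; within the scatter), or from the 2-chlorophenyl group, a 1.6-fold higher number from compound 1 to compound 4 (0.21 log units; within the scatter), so this place accepts three different substituted phenyl groups with no clear change. Only the 3-methoxyphenyl group stands apart, with an at least 2.1-fold lower number from compound 2 to compound 4 (0.32 log units; beyond the scatter). The value of compound 2 is a limit and not a true number: the limit of > 100000 nM in this assay, at which 1 of the 4 values shown sits.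

On these data alone, how an amine or a carboxylic acid on this phenyl ring would read remains open. So does the effect of a longer chain at this place.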